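The source may report more compounds than this note shows. Statements on the series, on what has been measured and on what is new or still open speak of the compounds shown alone.

The shared core is carried by compound 1 `O=c1[nH]c(=O)n([C@H]2C[C@H](O)[C@@H](CO)O2)cc1/C=N/O`, compound 2 `COCC#Cc1cn([C@H]2C[C@H](O)[C@@H](CO)O2)c(=O)[nH]c1=O` and compound 3 `CC#Cc1cn([C@H]2C[C@H](O)[C@@H](CO)O2)c(=O)[nH]c1=O`, which differ only in the group on an aromatic carbon. In an ADME assay on L1210/0 cells (Mus musculus) for cytotoxicity, with a stated time of 48 h (a lower number here means a stronger inhibitor, a higher number a weaker inhibitor), compound 1 gives 15500 nM. Compound 2 reaches only the limit of this assay, > 200000 nM. Compound 3 likewise returns only a limit, > 200000 nM, so among the measured numbers it stands at a floor rather than at a value: the limit of > 200000 nM in this assay, at which 2 of the 3 values shown sit. Among the measured compounds shown here, the step of an at least 12-fold higher number from compound 1 to compound 3 (1.11 log units; beyond the scatter) is the one measured change that bears on a plain carbon chain on an aromatic carbon here; the step that the two limits leave unreadable from compound 2 to compound 3 cannot be read. Compound 4 `CCCCCCc1cn([C@H]2C[C@H](O)[C@@H](CO)O2)c(=O)[nH]c1=O` is not yet measured; it carries hexyl in place of prop-1-yn-1-yl on an aromatic carbon. Since compound 3 already sits at the limit, no direction can be set from the numbers shown. The step expected in this assay is an at least 1.3-fold lower number from compound 3 to compound 4 (0.12 log units; that floor lies within the scatter). Compound 4 is therefore estimated to give 150000 nM, between 40000 nM and 500000 nM, with a fair chance that only a limit is reported again.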

Compound 4, half-maximal inhibitory concentration: > 200000 nM
Compound 4 ended at the assay's limit (the forecaster's own chance of this, stated with the estimate: 60%); middle value at least 1.3-fold (0.12 log units) from the limit.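

In this assay compound 4 returns only a limit, > 200000 nM. Among the compounds shown here, a chain without a triple bond therefore does no better on this aromatic carbon than the two alkynyl groups, and the change from the group of the first compound to hexyl gives an at least 12-fold higher number from compound 1 to compound 4 (1.11 log units; beyond the scatter), so the triple bond is not what this loss depends on. The steps among the three compounds at the limit cannot be read, and the picture at this position is now: the limit of > 200000 nM in this assay, at which 3 of the 4 values shown sit.

As far as these compounds go, how far these three chains differ from one another stays open, as does which feature of the nitrogen-and-oxygen-bearing group of compound 1 goes with its readable value. Whether a shorter chain such as ethyl, or a small group such as hydroxymethyl or an amine, would give a readable value on this carbon also remains unanswered.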